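Swapping a brominated phenyl for naphthalene on a thiazole-bearing pyrazoline

The source may report more compounds than this note shows. Statements on the series, on what has been measured and on what is new or still open speak of the compounds shown alone.

The three measured compounds share one core; compound 1 `NC(=S)N1N=C(c2ccc(N3CCCCC3)cc2)CC1c1ccc(Cl)cc1` carries a small sulfur-containing group on the ring nitrogen, compound 2 `Clc1ccc(C2CC(c3ccc(N4CCCCC4)cc3)=NN2c2nc(-c3ccccc3)cs2)cc1` a phenyl-substituted thiazole, and compound 3 `Clc1ccc(C2CC(c3ccc(N4CCCCC4)cc3)=NN2c2nc(-c3ccc(Br)cc3)cs2)cc1` the same thiazole with a brominated phenyl. In a functional assay on MCF7 cells (Homo sapiens) for antiproliferative activity, read by MTT assay, with a stated time of 72 h (a lower number here means a stronger inhibitor, a higher number a weaker inhibitor), compound 1 gives 22300 nM. Compound 2 gives 28400 nM, a change of a 1.3-fold higher number from compound 1 to compound 2 (0.11 log units; within the scatter). For compound 3 the assay reports only a limit, > 100000 nM. This places compound 3 as the weakest of the three, with steps of an at least 4.4-fold higher number from compound 1 to compound 3 (0.65 log units; beyond the scatter) and an at least 3.5-fold higher number from compound 2 to compound 3 (0.54 log units; beyond the scatter), both beyond the scatter (the limit of > 100000 nM in this assay, at which 1 of the 3 values shown sits).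

Compound 4 `Clc1ccc(C2CC(c3ccc(N4CCCCC4)cc3)=NN2c2nc(-c3ccc4ccccc4c3)cs2)cc1` differs from compound 3 by naphthalen-2-yl in place of 4-bromophenyl on an aromatic carbon. Among the measured compounds shown here, no measured step involves a naphthalene, so the only guide is that enlarging the thiazole's aryl group has so far not strengthened inhibition, as the step from compound 2 to compound 3 shows. Compound 4 is therefore expected to stay weak, with a step that the limit leaves unreadable from compound 3 to compound 4 estimated to be small, giving an expected value of 120000 nM, between 40000 nM and 300000 nM.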

Compound 4, half-maximal inhibitory concentration: > 100000 nM
Compound 4: no number, only a limit; the forecaster's own chance of this, stated with the estimate: 60%; the middle value lies beyond the limit too.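

Like compound 3, compound 4 gives only a limit in this assay, so the step between them cannot be read and these two groups cannot be ranked. What is new is that a group without bromine also falls behind the phenyl of compound 2, with an at least 3.5-fold higher number from compound 2 to compound 4 (0.54 log units; beyond the scatter): at this thiazole carbon, the loss seen with 4-bromophenyl does not require bromine, since naphthalen-2-yl shows it too. The thiazole compounds with these two groups now rest at the same limit: the limit of > 100000 nM in this assay, at which 2 of the 4 values shown sit.

Still open, going by these compounds, is whether a methyl on this thiazole carbon, or a phenyl bearing an amine or a carboxylic acid, would match or improve on compound 2 at 28400 nM. Also open, on these data alone, is whether a smaller halogen such as fluoro on that phenyl would be tolerated.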